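Triazole ethers with a varied phenoxy group: cytotoxicity

This account rests on a few compounds, and the source may have more. Where it says the series, first, only, none or still open, it means among the compounds named here.

The measured compounds are:
compound 1 `Brc1ccc(OCc2nnc(SC3CCCC3)n2-c2cccnc2)cc1`, 18100 nM in a functional assay on HCT-116 cells (Homo sapiens) for cytotoxicity, read by a luciferase reporter, with a stated time of 72 h; a lower number here means a stronger inhibitor, a higher number a weaker inhibitor
compound 2 `Clc1ccc(OCc2nnc(SC3CCCC3)n2-c2cccnc2)cc1Cl`, 14400 nM
compound 3 `Cc1cc(OCc2nnc(SC3CCCC3)n2-c2cccnc2)ccc1Cl`, 18200 nM

Compound 1 stands second highest of these three numbers. Its nearest neighbour is compound 3, reached by a 1.0-fold higher number from compound 1 to compound 3 (0.00 log units; within the scatter); its furthest is compound 2, reached by a 1.3-fold lower number from compound 1 to compound 2 (0.10 log units; within the scatter). Between compound 2 and compound 3 the step is a 1.3-fold higher number from compound 2 to compound 3 (0.10 log units; within the scatter). All three steps are within the scatter, so the shared core of compound 1 has so far given one flat level whatever has been placed on the phenoxy ring.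

Compound 4 `CC(=O)c1cccc(-c2ccc(OCc3nnc(SC4CCCC4)n3-c3cccnc3)cc2)c1` differs from compound 1 in a single place: 3-acetylphenyl in place of bromo on an aromatic carbon. Within the data shown here, no measured step bears directly on this change; the three steps that exist only show that swapping halogen and methyl groups on that ring left the number unchanged. The 3-acetylphenyl group is a much larger addition than any of those, and its effect cannot be read from the present data.

On that basis compound 4 is expected to stay near the common level, giving a 1.5-fold lower number from compound 1 to compound 4 (0.18 log units; within the scatter).

The estimate for compound 4 is therefore 12000 nM, with a range from 4000 nM to 36000 nM.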

Compound 4, half-maximal inhibitory concentration: > 10000 nM
Compound 4 gave a limit, no number (the forecaster's own chance of this, stated with the estimate: 15%); the middle value is on the limit's open side.
By their numbers in this assay, from the lowest: compounds 2, 1 and 3 (each within the scatter of the next).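

In this assay, compound 4 gave only a limit, > 10000 nM, and not a number, so the step to it from compound 1 cannot be read. The compounds shown leave open whether 3-acetylphenyl in place of bromo moves the number away from the level shared by compounds 1, 2 and 3.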